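A few compounds are considered here, and "the series" means these few. Any claim that something is new, unique, unknown or untested is made for them only; others in the source may bear on it.

Of the compounds shown here, three built on one shared core have been measured in a functional assay on CRL2813 cells (Homo sapiens) for cytotoxicity, read by sulforhodamine B assay, with a stated time of 5 days (on this read-out higher numbers stand for weaker inhibition and lower numbers for stronger inhibition), and none of them gives a number inside the tested range. Compound 1 `Cc1ccc(NC(=O)N[C@H]2CC[C@H](Oc3ccc(F)cc3)CC2)cc1` gives only a limit in this assay, > 20000 nM. Compound 2 `O=C(Nc1ccccc1I)N[C@H]1CC[C@H](Oc2ccc(F)cc2)CC1` also gives only a limit in this assay, > 20000 nM. Compound 3 `O=C(Nc1ccc(F)cc1)N[C@H]1CC[C@H](Oc2ccc(F)cc2)CC1` gives 20000 nM in this assay. Compound 2 thus stands at the limit of > 20000 nM in this assay, at which 2 of the 3 values shown sit, and the steps among the three measured compounds are all of unreadable size: a step that the two limits leave unreadable from compound 1 to compound 2, a number no higher from compound 1 to compound 3 (the limit leaves the size open) and a number no higher from compound 2 to compound 3 (the limit leaves the size open).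

Compound 4 `O=C(Nc1ccccc1C(F)(F)F)N[C@H]1CC[C@H](Oc2ccc(F)cc2)CC1` differs from compound 2 by a single change: trifluoromethyl in place of iodo on an aromatic carbon. Going by the values given here, no measured step touches this particular change, and the steps that do exist on the shared core all resolve to no readable size, so they offer no direction for it. Among the compounds with values here, the three measured compounds, compound 1, compound 2 and compound 3, sit together at or beyond the top of the range, with no compound going against that.

Compound 4 is therefore expected to sit where compound 2 sits, with an estimated value of 20000 nM, spanning 8000 nM to 50000 nM, and the expected step of a number no higher from compound 2 to compound 4 (the limit leaves the size open) is judged to be none beyond the scatter, most likely reported again only as a limit.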

Compound 4, half-maximal inhibitory concentration: > 20000 nM
Compound 4: a limit, no number; the forecaster's own chance of this, stated with the estimate: 80%; the middle value sits exactly at the limit.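

In this assay compound 4 gives > 20000 nM which is a limit and not a number. Going by these compounds alone, compound 2 also gives only a limit, so no step between compound 2 and compound 4 can be read. The compounds shown leave open whether trifluoromethyl in place of iodo changes the read-out at all, and what actual numbers compound 2 and compound 4 would give.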